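Chloro Added to a Cytotoxicity-Silent Hydrazide Series

The source may report more compounds than this note shows. Statements on the series, on what has been measured and on what is new or still open speak of the compounds shown alone.

Compound 1 `CC(C)CN(NC(=O)C1CCC(=O)CC1)c1nc(C#N)ncc1Br`: > 100000 nM
Compound 2 `CC(C)CN(NC(=O)C1CCC2(CC1)OOC1(OO2)C2CC3CC(C2)CC1C3)c1ccnc(C#N)n1`: > 100000 nM
Compound 3 `N#Cc1ncc(Br)c(N(CC2CCCC2)NC(=O)C2CCC3(CC2)OOC2(OO3)C3CC4CC(C3)CC2C4)n1`: > 100000 nM

All three measured compounds were examined in an ADME assay on HEK-293T cells (Homo sapiens) for cytotoxicity; on this read-out higher numbers stand for lower toxicity in this test and lower numbers for higher toxicity in this test. For compound 1 the reported figure is a limit of the test rather than a number, > 100000 nM. For compound 2 the result is likewise only a limit, > 100000 nM. For compound 3 the value is again a limit, > 100000 nM. Among the compounds with values here, compound 2 thus stands where every other measured compound stands, at the limit of > 100000 nM in this assay, at which 3 of the 3 values shown sit, and no two measured compounds differ in a single place, so no step in this assay can be read from the numbers as they are.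

Compound 4 `CC(C)CN(NC(=O)C1CCC2(CC1)OOC1(OO2)C2CC3CC(C2)CC1C3)c1cc(Cl)nc(C#N)n1` differs from compound 2 in one place: chloro in place of hydrogen on an aromatic carbon. With every measured compound sitting at the same limit, the step in this assay is expected to be none beyond the scatter, a step that the limit leaves unreadable from compound 2 to compound 4. Compound 4 is expected to give 150000 nM, between 100000 nM and 300000 nM, most likely reported once more only as a limit.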

Compound 4, half-maximal cytotoxic concentration: > 100000 nM
Compound 4: only a limit was reported; the forecaster's own chance of this, stated with the estimate: 85%; the middle value is on the limit's open side.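

In this assay compound 4 gives only a limit, > 100000 nM. Compound 2 is likewise reported only as a limit, so no step can be read between compound 2 and compound 4. The compounds shown leave open what chloro in place of hydrogen does to this read-out.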